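Compound 1 loses a methyl from its core

This account rests on a few compounds, and the source may have more. Where it says the series, first, only, none or still open, it means among the compounds named here.

Going by the values given here, in a functional assay (Mus musculus) for inhibition, read by cell counting, with a stated time of 3 days (a lower number here means a stronger inhibitor, a higher number a weaker inhibitor), compound 1 `COc1ccc(N(C)c2nc(C)nc3c2nc(C)n3C)cc1` gives 8700 nM, the only measured number among the three compounds tested so far. Compound 2 `COc1ccc(Nc2nc(C)nc3c2nc(C)n3C)cc1` gives >= 100000 nM, which is a limit of the assay. Compound 3 `Cc1nc(N(C)c2ccc(OC(F)(F)F)cc2)c2nc(C)n(C)c2n1` gives > 100000 nM, which is also a limit.

Compound 4 `COc1ccc(N(C)c2ncnc3c2nc(C)n3C)cc1` has hydrogen in place of methyl on an aromatic carbon, between two ring nitrogen atoms (hydrogen in place of methyl on an aromatic carbon). Among the compounds with values here, two measured steps bear on this change, though neither touches that carbon. Hydrogen in place of methyl on a nitrogen on an aromatic ring gives an at least 11-fold higher number from compound 1 to compound 2 (1.06 log units; beyond the scatter), the closest parallel. Trifluoromethyl in place of methyl on an oxygen on an aromatic ring gives an at least 11-fold higher number from compound 1 to compound 3 (1.06 log units; beyond the scatter). Within the data shown here, both edits to compound 1 were large and raised the number, and no compound goes against that direction. Among the measured compounds shown here, a rise beyond the scatter is therefore expected here too, probably a smaller one, although this assay has no direct precedent for this position. The expected step is a 2.9-fold higher number from compound 1 to compound 4 (0.46 log units; beyond the scatter). Compound 4 is estimated at 25000 nM, with an expected range from 6000 nM to 100000 nM.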

Compound 4, half-maximal inhibitory concentration: >= 100000 nM
Compound 4: a limit, no number; the forecaster's own chance of this, stated with the estimate: 35%; at least 4.0-fold (0.60 log units) between middle value and limit.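

In this assay, the methyl on the aromatic carbon between two ring nitrogen atoms proves as necessary to a measurable number as the two groups changed earlier: hydrogen in its place gives an at least 11-fold higher number from compound 1 to compound 4 (1.06 log units; beyond the scatter). Going by these compounds alone, the earlier compounds touched only the nitrogen and oxygen substituents, so this is the first sign that the core of compound 1 also tolerates change poorly, and the loss of this single methyl reaches the same limit as those edits. Compound 4 stands at a limit and not at a number, so the true size of this step cannot be read: the limit of >= 100000 nM in this assay, at which 2 of the 4 values shown sit.

The compounds shown leave open whether ethyl, an amine or a chlorine atom on this carbon would restore a measured number. They also leave open whether any single change to compound 1 can lower its number.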